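Swapping chloro for fluoro on a strong growth inhibitor

A few compounds are considered here, and "the series" means these few. Any claim that something is new, unique, unknown or untested is made for them only; others in the source may bear on it.

In a functional assay on MDA-MB-435 cells (Homo sapiens) for antiproliferative activity (on this read-out higher numbers stand for weaker inhibition of growth and lower numbers for stronger inhibition of growth), compound 1 `Cc1cccc(-c2cc(O)c3ccc(C)nc3n2)c1` gives 32.4 nM as its result, and compound 2 `Cc1cc(C)c2c(O)cc(-c3cccc(Cl)c3)nc2n1` gives 13.2 nM as its result. Compound 3 `Cc1cnc2[nH]c(-c3cccc(Cl)c3)cc(=O)c2c1` is reported as < 10 nM and that is only a limit of the assay, not a number. Compound 4 `Cc1cnc2[nH]c(-c3cccc(F)c3)cc(=O)c2c1` has not been measured yet. It differs from compound 3 in one place, with fluoro in place of chloro on an aromatic carbon, meta to a large group (fluoro in place of chloro on an aromatic carbon). Among the measured compounds shown here, no measured pair shows this exchange, so the guide is thin. In this assay the expected at least 1.4-fold higher number from compound 3 to compound 4 (0.14 log units; that floor lies within the scatter) is modest, leaning towards weaker inhibition of growth, and may not exceed the usual scatter. For compound 4 the estimated value is 14 nM with an expected range from 4 nM to 50 nM in repeat measurements.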

Compound 4, concentration for 50% growth inhibition: < 10 nM
Compound 4: no number, only a limit (the forecaster's own chance of this, stated with the estimate: 40%); at least 1.4-fold (0.14 log units) between middle value and limit.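

Compound 3 and compound 4 both give only a limit, not a number, so no step can be read for fluoro in place of chloro, because both rest on the same limit: the limit of < 10 nM in this assay, at which 2 of the 4 values shown sit.

Going by these compounds, whether either group gives stronger inhibition of growth remains open.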